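The source may hold more compounds than are shown below. What is called first, only, known or untested is meant among the compounds shown, and "the series" means these compounds.

In a physicochemical assay for lipophilicity, read by HPLC, at pH 7.4 (a lower number here means a more polar compound, a higher number a more lipophilic compound), compound 3 (`CS(=O)(=O)c1ccc(-c2cnc(N)c(-c3ccc(C(F)(F)F)cc3)c2)cc1`) gives 3.4, within the scatter of compound 1 (`Cc1ccc(-c2cc(-c3ccc(S(C)(=O)=O)cc3)cnc2N)cc1C(F)(F)F`) at 3.6 and of compound 2 (`CS(=O)(=O)c1ccc(-c2cnc(N)c(-c3ccc(C(F)(F)F)c(F)c3)c2)cc1`) at 3.1. Compound 4 (`CS(=O)(=O)c1ccc(-c2cnc(N)c(-c3ccc(C(N)=O)cc3)c2)cc1`) has carbamoyl in place of trifluoromethyl on an aromatic carbon, para to a large group: carbamoyl in place of trifluoromethyl on an aromatic carbon. Among the compounds with values here, the only measured step, a number 0.30 log units higher from compound 2 to compound 3 (within the scatter), is hydrogen in place of fluoro on an aromatic carbon. It involves neither carbamoyl nor trifluoromethyl, so the series gives no measured size for this change. Resting on the structural change alone, the expected step in this assay is downward, a number 1.40 log units lower from compound 3 to compound 4 (beyond the scatter), well beyond the scatter. For compound 4 the estimated value is 2, with an expected range of 1.5 to 2.5.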

Compound 4, distribution coefficient: 1.5
Beside the measured number, compound 4's estimate is 0.50 log units above it; measured number inside the range.
By their numbers in this assay, from the lowest: compound 4; then compounds 2, 3 and 1 (each within the scatter of the next, the first and the last beyond it).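

In this assay, replacing trifluoromethyl with carbamoyl on this aromatic carbon, para to a large group, gives a number 1.90 log units lower from compound 3 to compound 4 (beyond the scatter), so the group at this place can move the number well beyond the scatter. Within the data shown here, the only earlier step on this ring, a number 0.30 log units higher from compound 2 to compound 3 (within the scatter), did not show that. No measurement shown accounts for the size of the new step.

From the compounds shown here alone, whether a nitrile or a carboxylic acid at this place would give a step of similar size remains open. So does the effect of adding a methyl group to the amide nitrogen.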